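A few compounds are considered here, and "the series" means these few. Any claim that something is new, unique, unknown or untested is made for them only; others in the source may bear on it.

Compound 1 `CCCc1ccc(NC(=O)N[C@@H](C)c2ccccc2)cc1` and compound 2 `CCCCCCCc1ccc(NC(=O)N[C@@H](C)c2ccccc2)cc1` share one core. In an ADME assay on the whole organism with Oryza sativa as the target, tested at 1 uM (on this read-out higher numbers stand for a weaker effect at the one concentration tested and lower numbers for a stronger effect), compound 1 gives 76%, while compound 2 gives 99%. The step of a number 23 percentage points higher from compound 1 to compound 2 (beyond the scatter) separates them, so compound 2 stands highest of the two numbers, beyond the scatter from compound 1. Compound 3 `C[C@H](NC(=O)Nc1ccc(Br)cc1)c1ccccc1` differs from compound 2 in a single place: bromo in place of heptyl on an aromatic carbon. Going by the values given here, the only measured step that bears on this change is a number 23 percentage points higher from compound 1 to compound 2 (beyond the scatter), a modest rise when the chain was lengthened; with the chain replaced by bromo, a step back is expected, namely a number 29 percentage points lower from compound 2 to compound 3 (beyond the scatter) in this assay. Compound 3 is therefore estimated at 70% in this assay, within 50% to 95%.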

Compound 3, a percentage reported as activity, at one concentration (the size of the read-out at that concentration, not a potency): 97%
Estimate against measurement, compound 3: 27 percentage points below; the measured number lies above the stated range.
By their numbers in this assay, from the lowest: compound 1; then compounds 3 and 2 (each within the scatter of the next).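

In this assay, the change from heptyl to bromo on this aromatic carbon gives a number 2 percentage points lower from compound 2 to compound 3 (within the scatter), so a single bromine atom and a seven-carbon chain read alike here. The step of a number 21 percentage points higher from compound 1 to compound 3 (beyond the scatter) shows that bromo in place of propyl moves the number as far as the longer chain did, which means the read-out does not track the size of the group at this position. Nothing measured here accounts for this result. On these data alone, it remains open whether an amine or a carboxylic acid at this position would read like compound 1 or like compound 2 and compound 3.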